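The source may report more compounds than this note shows. Statements on the series, on what has been measured and on what is new or still open speak of the compounds shown alone.

Compound 1, `CCC(CC)O[C@@H]1C=C([S+]([O-])O)C[C@H](N)[C@H]1NC(C)=O`, and compound 2, `CCC(CC)O[C@@H]1C=C([S+]([O-])O)C[C@H](NC(=N)N)[C@H]1NC(C)=O`, share a core that carries an amine nitrogen on a saturated ring carbon; compound 2 differs from compound 1 by a group of 3 heavy atoms (1 carbon, 2 nitrogen; no ring) in place of a hydrogen atom, on an amine nitrogen. In an ADME assay on MDCK cells (Canis lupus familiaris) for cytotoxicity, with a stated time of 48 h (a lower number here means that less compound is tolerated, a higher number that more compound is tolerated), compound 1 reaches only a limit of the assay, > 100000 nM. In this assay compound 2 likewise reaches only a limit, > 100000 nM. The step that the two limits leave unreadable from compound 1 to compound 2 therefore cannot be read, because both values sit at the limit of > 100000 nM in this assay, at which 2 of the 3 values shown sit.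

Compound 3, `CCC(CC)O[C@@H]1C=C(S(=O)(=O)OCCCc2ccccc2)C[C@H](N)[C@H]1NC(C)=O`, is built on a second core; how it differs from compound 1 is not broken down here. In this assay compound 3 stands as "not determined" (no result reported), so no result for it has been reported. Compound 4, `CCC(CC)O[C@@H]1C=C(S(=O)(=O)OCCCc2ccccc2)C[C@H](NC(=N)N)[C@H]1NC(C)=O`, has not yet been measured in this assay; it differs from compound 3 by a group of 3 heavy atoms (1 carbon, 2 nitrogen; no ring) in place of a hydrogen atom, on an amine nitrogen, which is the same change as that from compound 1 to compound 2, on the same kind of place. Since the earlier step could not be sized, and since compound 3 itself has no value, nothing measured fixes the step from compound 3 to compound 4. What can be said rests only on compound 1 and compound 2, both of which stand at the assay limit in this assay. On that basis compound 4 is expected to give about 100000 nM in this assay, with the estimate ranging from 30000 nM to 300000 nM, and with a real chance that only a limit is reported again.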

Compound 4, half-maximal cytotoxic concentration: > 100000 nM
Compound 4 gave a limit, no number; the forecaster's own chance of this, stated with the estimate: 70%; the middle value sits exactly at the limit.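

In this assay, among these compounds, compound 4 gives > 100000 nM, which is a limit of the assay and not a number, and no step from compound 3 to compound 4 can be read. Compound 4 stands with compound 1 and compound 2 at the same limit: the limit of > 100000 nM in this assay, at which 3 of the 4 values shown sit.

The compounds shown leave open at what concentration any of these three reaches its half-maximal cytotoxic effect, and whether the change on the amine nitrogen alters that concentration at all.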